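A few compounds are considered here, and "the series" means these few. Any claim that something is new, unique, unknown or untested is made for them only; others in the source may bear on it.

Measured compounds:
- compound 1, `Cc1nc(Cc2ccccc2)c2ncnc(O)n12`: 263000 nM in a functional assay on CCRF-CEM cells (Homo sapiens) for cytotoxicity; a lower number here means that less compound is tolerated, a higher number that more compound is tolerated
- compound 2, `Cc1ncn2c(S)ncnc12`: 789000 nM in this assay

For the measured compounds named here, of these two numbers, compound 2 stands highest in this assay; the only other value, that of compound 1, is lower by a gap beyond the usual scatter. Compound 3, `Cc1nc(C)n2c(S)ncnc12`, has not yet been tested. It differs from compound 2 by methyl in place of hydrogen on an aromatic carbon. Going by the values given here, no single-change pair among the measured compounds shows what such a methyl does here, so the step is expected to be small, in no firm direction, and likely within the scatter. For compound 3 the expected value in this assay is 600000 nM, between 200000 nM and 1800000 nM, a step of a 1.3-fold lower number from compound 2 to compound 3 (0.12 log units; within the scatter).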

Compound 3, half-maximal cytotoxic concentration: > 694000 nM
Compound 3 gave a limit, no number; the forecaster's own chance of this, stated with the estimate: 30%; middle value at least 1.1-fold (0.06 log units) away from the limit.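

Compound 3 gives > 694000 nM, which is a limit of the assay and not a number, so no step can be read from compound 2 to compound 3. As far as these compounds go, what methyl in place of hydrogen on an aromatic carbon does in this assay stays open.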